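A few compounds are considered here, and "the series" means these few. Any claim that something is new, unique, unknown or untested is made for them only; others in the source may bear on it.

Working notes on the series. The read-out followed here is a physicochemical assay for solubility, in phosphate buffer; on this read-out higher numbers stand for higher solubility and lower numbers for lower solubility. Of the compounds shown here, two carry a number so far. Compound 1 `Cc1nc(N2CCN(C(=O)C3CCC3)CC2)nc2ccc(NC(=O)COc3ccc(OC(F)(F)F)cc3)cc12` in this assay gives 4000 nM. Within the data shown here, compound 2 `Cc1nc(N2CCC(C(=O)NC(C)C)CC2)nc2ccc(NC(=O)COc3ccc(Cl)cc3)cc12` in this assay gives 132000 nM, the higher of the two numbers; the gap to compound 1 lies beyond the usual scatter of this read-out, and no single-point step connects the two, as they differ in more than one place.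

Compound 3 `Cc1nc(N2CCC(NC(=O)C(C)C)CC2)nc2ccc(NC(=O)COc3ccc(Cl)cc3)cc12` is the next compound and has not yet been measured in this assay. It differs from compound 2 in one place: (isopropylcarbonyl)amino in place of isopropylcarbamoyl on a saturated ring carbon. The two share the same atoms, joined differently, and the donor and acceptor count of the group is unchanged.

Among the measured compounds shown here, nothing among the measured compounds maps this kind of reversal onto solubility, so the expectation rests on compound 2 alone. The step from compound 2 to compound 3 is expected to be small, a 1.3-fold lower number from compound 2 to compound 3 (0.12 log units; within the scatter), within the scatter, in no firm direction. Compound 3 in this assay is therefore estimated at 100000 nM, with a range from 35000 nM to 300000 nM.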

Compound 3, solubility: 205000 nM
For compound 3 the middle estimate is 2.1-fold (0.31 log units) below the measured one; the measured number falls inside the stated range.
By their numbers in this assay, from the lowest: compound 1; then compounds 2 and 3 (each within the scatter of the next).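

In this assay the exchange of isopropylcarbamoyl for (isopropylcarbonyl)amino on the saturated ring carbon is a 1.6-fold higher number from compound 2 to compound 3 (0.19 log units; within the scatter) and gives the series its first single-point step. The same atoms, joined the other way round at this place, leave compound 2 and compound 3 indistinguishable on this read-out, so the direction of the amide does not separate them here. No measurement at hand accounts for this outcome, and the step is read only as a size.

The compounds shown leave open how this read-out responds when the saturated ring carbon carries a group of another kind, such as an amine or a carboxylic acid, rather than a rearrangement of the same atoms. They also leave open whether the reversal reads the same with a longer chain in place of the isopropyl part of the amide, or with the trifluoromethoxy group of compound 1 in place of the chlorine, since compound 1 is linked to neither compound 2 nor compound 3 by a single-point step.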